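Cytotoxicity of a Quinolinone Amine Series: Toward Compound 4

This account rests on a few compounds, and the source may have more. Where it says the series, first, only, none or still open, it means among the compounds named here.

Compound 1 `C[C@@H](c1ccc(OC(F)(F)F)cc1)N(Cc1ccc(C(C)(C)C)cc1)Cc1cc2cc(C(F)(F)F)ccc2[nH]c1=O`: > 10000 nM
Compound 2 `C[C@@H](c1ccc(OC(F)(F)F)cc1)N(Cc1ccc(C(C)(C)C)cc1)Cc1cc2cc(C3CC3)ccc2[nH]c1=O`: > 10000 nM
Compound 3 `C[C@H](c1ccc(OC(F)(F)F)cc1)N(Cc1ccc(C(C)(C)C)cc1)Cc1cc2cc(C3CC3)ccc2[nH]c1=O`: "not determined" (no result reported)

In a toxicity assay on MDCK cells (Canis lupus familiaris) for cytotoxicity, read by crystal violet staining, with a stated time of 48 h (on this read-out lower numbers stand for higher toxicity in this test and higher numbers for lower toxicity in this test), compound 2 gives only a limit, > 10000 nM. Compound 1 likewise gives only a limit in this assay, > 10000 nM. Among the compounds with values here, the single step that joins them, a step that the two limits leave unreadable from compound 1 to compound 2, is therefore unreadable, a consequence of the limit of > 10000 nM in this assay, at which 2 of the 3 values shown sit. Compound 3 differs from compound 2 solely as stated in the fact that compounds 2 and 3 differ only in the configuration as drawn, and no result was reported for it. Compound 4 `C[C@@H](c1ccc(OC(F)(F)F)cc1)N(Cc1ccc(C(F)(F)F)c(Cl)c1)Cc1cc2cc(C3CC3)ccc2[nH]c1=O` carries 3-chloro-4-(trifluoromethyl)phenyl in place of 4-(tert-butyl)phenyl on a saturated chain carbon bound to an amine nitrogen. Within the data shown here, no measured step bears on this change, and the only readable fact is that two of three values rest at the limit. Compound 4 is therefore expected to stay at that limit, with a step of a number no higher from compound 2 to compound 4 (the limit leaves the size open) not beyond the scatter. The estimate for compound 4 in this assay is 10000 nM, ranging from 3000 nM to 30000 nM.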

Compound 4, half-maximal cytotoxic concentration: 7900 nM
The estimate for compound 4 lay 1.3-fold (0.10 log units) above the measured number, within the range that was stated.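

In this assay, within the data shown here, compound 4 gives 7900 nM, the only value in this set that is a number and not a limit. Compound 2 gives > 10000 nM, which is a limit. Replacing 4-(tert-butyl)phenyl with 3-chloro-4-(trifluoromethyl)phenyl on a saturated chain carbon bound to an amine nitrogen gives an at least 1.2-fold lower number from compound 2 to compound 4 (0.10 log units; that floor lies within the scatter), so this change is not shown to exceed the usual scatter.

Going by these compounds, the true size of that step stays open, and the set still rests largely on one bound: the limit of > 10000 nM in this assay, at which 2 of the 4 values shown sit. Whether a carboxylic acid or a longer chain at this position would give a number also remains open.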